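From Compound 3 to Compound 4: A Ring Exchange

This account rests on a few compounds, and the source may have more. Where it says the series, first, only, none or still open, it means among the compounds named here.

Three close relatives have been tested in a functional assay on MCF7 cells (Homo sapiens) for cytotoxicity, read by CellTiter-Glo, with a stated time of 5 days; a higher number here means a weaker inhibitor, a lower number a stronger inhibitor. Compound 1 `CC/C(=C(/c1ccc(/C=C/C(=O)O)cc1)c1ccc2[nH]ncc2c1)c1ccccc1` gives 6 nM, compound 2 `CC/C(=C(/c1ccc(/C=C/C(=O)O)cc1)c1ccc2[nH]ncc2c1)c1ccc(Cl)cc1` gives 15 nM, and compound 3 `CC/C(=C(/c1ccc(/C=C/C(=O)O)cc1)c1ccc2[nH]ncc2c1)c1ccc(C#N)cc1C` gives 5 nM. The data show a 1.2-fold lower number from compound 1 to compound 3 (0.08 log units; within the scatter), and they also show a 3.0-fold lower number from compound 2 to compound 3 (0.48 log units; beyond the scatter). Compound 3 therefore shares the low end of these numbers with compound 1, while compound 2 stands apart.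

Compound 4 `CC/C(=C(/c1ccc(/C=C/C(=O)O)cc1)c1ccc2[nH]ncc2c1)c1cnccc1C` keeps the shared core but carries 4-methylpyridin-3-yl in place of 4-cyano-2-methylphenyl on a double-bonded chain carbon bound to a double-bonded chain carbon and a saturated chain carbon. The three measured steps all involve this same group, and the third is a 2.5-fold higher number from compound 1 to compound 2 (0.40 log units; beyond the scatter). None of them brings in a ring with a hetero atom, so the data do not test this exchange directly. The steps seen there stay modest, so a step of similar size, leaning toward a higher number, is expected in this assay. The expected change is a 1.8-fold higher number from compound 3 to compound 4 (0.26 log units; within the scatter). Compound 4 is estimated at 9 nM, with an expected range of 3 nM to 30 nM.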

Compound 4, half-maximal inhibitory concentration: 150 nM
For compound 4 the middle estimate is 17-fold (1.22 log units) below the measured one; measured number above the stated range.
By their numbers in this assay, from the lowest: compounds 3 and 1 (each within the scatter of the next); then compound 2; then compound 4.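

In this assay, among the compounds shown here, this place on the double-bonded chain carbon proves far less tolerant than the earlier compounds could show, as 4-methylpyridin-3-yl brings a 30-fold higher number from compound 3 to compound 4 (1.48 log units; beyond the scatter) and a 25-fold higher number from compound 1 to compound 4 (1.40 log units; beyond the scatter) and also a 10-fold higher number from compound 2 to compound 4 (1.00 log units; beyond the scatter) in the same series. All three rings of carbon only, whether phenyl, 4-chlorophenyl or 4-cyano-2-methylphenyl, therefore give lower numbers than this one ring with a hetero atom, although that contrast rests on compound 4 alone. Nothing available explains why the number rises so sharply.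

4-methylpyridin-3-yl differs from 4-cyano-2-methylphenyl both in its ring nitrogen and in the lost nitrile, and the compounds shown do not separate these two changes. Going by these compounds, it also remains open whether a nitrile, an amine or a methoxy group on the 4-methylpyridin-3-yl ring would bring the number back down.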